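Stereoisomers at the assay limit, and one still unmeasured

The compounds below may be only part of what the source reports. "The series", "measured", "known", "first", "only" and "open" are said of these compounds alone.

Compound 1 `O=C(O)[C@H](CO)NC(=O)[C@H]1C[C@H](O)CN1`: > 12 h (a limit)
Compound 2 `O=C(O)[C@@H](CO)NC(=O)[C@H]1C[C@H](O)CN1`: > 12 h (a limit)
Compound 3 `O=C(O)[C@H](CO)NC(=O)[C@@H]1C[C@H](O)CN1`: > 12 h (a limit)

In an ADME assay for metabolic stability, read by HPLC, in simulated intestinal fluid, with a stated time of 12 h, at pH 6.8 (on this read-out higher numbers stand for a longer-lived compound and lower numbers for a shorter-lived compound), compound 2 gives > 12 h and this is a limit of the assay, not a number. Among the measured compounds shown here, the other two readings are limits as well, so no measured compound can be ranked against another.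

Compound 4 `O=C(N[C@H](CO)C(=O)O)[C@@H]1C[C@@H](O)CN1` has not yet been measured. The structural change from compound 2 is the two compounds have the same atoms and bonds and differ only in configuration as drawn: 2 of 3 stereo elements differ; a stereocentre at a saturated ring carbon is drawn R in compound 2 and S in compound 4; a stereocentre at a saturated ring carbon is drawn S in compound 2 and R in compound 4 and the atoms and bonds stay the same.

The closest guide is a step that the two limits leave unreadable from compound 2 to compound 3 with a ring carbon changed there too. The other guides are a step that the two limits leave unreadable from compound 1 to compound 2 and a step that the two limits leave unreadable from compound 1 to compound 3 and each of them changes configuration alone. None of these steps has a readable size, yet all of them join compounds that sit at the limit. No step beyond the usual scatter is therefore expected in this assay and no direction can be given.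

The estimated change is a step that the limit leaves unreadable from compound 2 to compound 4 as the expected outcome. Compound 4 is expected at about 15 h with an estimated range from 10 h to 30 h and it will probably be reported only as a limit.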

Compound 4, half-life: > 12 h
Compound 4: no number, only a limit; the forecaster's own chance of this, stated with the estimate: 90%; the middle value is on the limit's open side.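

In this assay, among the compounds shown here, compound 4 sits at the same limit as compound 1, compound 2 and compound 3, so no step between compound 4 and any of them can be read. The compounds shown leave open how long each one actually lasts and whether configuration changes that at all.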